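Halogen swap on the shared core: cytotoxicity notes

The compounds below may be only part of what the source reports. "The series", "measured", "known", "first", "only" and "open" are said of these compounds alone.

compound 1 `CN1CCC(NC(=O)c2ccc(Nc3ncc(Cl)c(NC4CCCC4)n3)cc2)CC1` — 4600 nM in a functional assay on HCT-8 cells (Homo sapiens) for cytotoxicity, read by MTT assay, with a stated time of 48 h; a higher number here means a weaker inhibitor, a lower number a stronger inhibitor
compound 2 `COc1cc(C(=O)NC2CCN(C)CC2)ccc1Nc1ncc(Cl)c(NC2CCCC2)n1` — 4400 nM
compound 3 `CCCNc1nc(Nc2ccc(N3CCN(C)CC3)cc2)ncc1F` — 50000 nM

Compound 2 holds the lowest of the three numbers in this assay. Compound 1 sits within the scatter of it, while compound 3 lies furthest away, beyond the scatter. Within the data shown here, the only measured step between compounds that differ in one place is a 1.0-fold lower number from compound 1 to compound 2 (0.02 log units; within the scatter), a methoxy change on the aromatic carbon; it does not touch the halogen on the core.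

Compound 4 `COc1cc(C(=O)NC2CCN(C)CC2)ccc1Nc1ncc(F)c(NC2CCCC2)n1` is the next candidate. Its change from compound 2 is fluoro in place of chloro on an aromatic carbon. Among the measured compounds shown here, no measured step covers this swap. Compound 3 also carries a fluoro on the same core, but it differs from compound 2 in several further places, so its number says little about the halogen alone.

For the measured compounds named here, with no step bearing directly on the change, the expected shift in this assay is none beyond the scatter, with a mild lean towards a higher number. Compound 4 is therefore expected to give 6500 nM (range 2500 nM to 17000 nM), an estimated step of a 1.5-fold higher number from compound 2 to compound 4 (0.17 log units; within the scatter).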

Compound 4, half-maximal inhibitory concentration: 2100 nM
For compound 4 the middle estimate is 3.1-fold (0.49 log units) above the measured one; measured number outside the range, below it.
By their numbers in this assay, from the lowest: compound 4; then compounds 2 and 1 (each within the scatter of the next); then compound 3.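

In this assay, among these compounds, the halogen on the shared core now has a measured step of its own, a 2.1-fold lower number from compound 2 to compound 4 (0.32 log units; beyond the scatter), whereas the only earlier step, a 1.0-fold lower number from compound 1 to compound 2 (0.02 log units; within the scatter), left this position untouched. On this single pair, fluoro in place of chloro on the aromatic carbon ortho to a cyclopentylamino group is tolerated, with the number moving modestly down rather than up. Nothing measured on these compounds accounts for the step.

The compounds shown leave open whether the step is particular to fluoro or whether bromo, methyl or nitrile at this position would give a similar number. On these data alone, it also remains open whether the same swap would hold on the core of compound 1, which has hydrogen in place of the methoxy group.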